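Demethylation on the core: compound 2 to compound 3

This account rests on a few compounds, and the source may have more. Where it says the series, first, only, none or still open, it means among the compounds named here.

Within the data shown here, compound 2 `COc1cc(OC)c(C(=O)/C=C/c2ccccc2SC)c(OC)c1` gives 0% in a functional assay on HaCaT cells (Homo sapiens), read by fluorescence and BrdU incorporation, with a stated time of 48 h, tested at 25 uM (a lower number here means a stronger effect, a higher number a weaker effect of the compound at the concentration tested), the lowest of the two numbers so far; compound 1 `COc1cc(OC)c(C(=O)/C=C/c2ccc(Br)cc2)c(OC)c1` gives 0.3%, and the step of a number 0.3 percentage points lower from compound 1 to compound 2 (within the scatter) lies within the scatter. Compound 3 `COc1cc(O)c(C(=O)/C=C/c2ccccc2SC)c(OC)c1` differs from compound 2 by hydrogen in place of methyl on an oxygen on an aromatic ring. Among the measured compounds shown here, the only measured step, a number 0.3 percentage points lower from compound 1 to compound 2 (within the scatter), changes the other ring and so does not bear on a change at the core; nothing measured here does. No step beyond the scatter is therefore expected, and the expected step is a number 2 percentage points higher from compound 2 to compound 3 (within the scatter). For compound 3 the estimate is 2%, within 0% to 12%.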

Compound 3, a percentage reported as activity, at one concentration (the size of the read-out at that concentration, not a potency): 30%
Beside the measured number, compound 3's estimate is 28 percentage points below it; the whole stated range lies below it.
By their numbers in this assay, from the lowest: compounds 2 and 1 (each within the scatter of the next); then compound 3.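

In this assay, hydrogen in place of methyl on an oxygen on an aromatic ring gives a number 30 percentage points higher from compound 2 to compound 3 (beyond the scatter), so the effect at the concentration tested is weaker. Among these compounds, this is the first single change to move the read-out beyond the scatter, and it shows that this methoxy group on the shared core is not interchangeable with hydroxy. No measurement on hand explains the step.

As far as these compounds go, whether the other methoxy groups on the core respond in the same way remains open. So does the outcome with ethoxy or an amine at this position.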